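This account rests on a few compounds, and the source may have more. Where it says the series, first, only, none or still open, it means among the compounds named here.

Measured compounds in an assay for inhibition of 6-phosphofructo-2-kinase/fructose-2,6-bisphosphatase 3 (Homo sapiens), read by ADP-Glo, with a stated time of 2 h; on this read-out higher numbers stand for weaker inhibition and lower numbers for stronger inhibition:
compound 1 `Cn1ccc2ccc(-c3cc(Nc4cnccc4C(=O)NCc4cncnc4)cc4nccnc34)cc21` gives 106 nM
compound 2 `CN1CC(NC(=O)c2ccncc2Nc2cc(-c3ccc4ccn(C)c4c3)c3nccnc3c2)CCC1=O` gives 116 nM

Compound 2 stands at the higher of the two numbers, with compound 1 nearest; the step of a 1.1-fold higher number from compound 1 to compound 2 (0.04 log units; within the scatter) is within the scatter, so the two compounds cannot be ordered on this read-out. That step exchanged one substituent on the amide-type nitrogen, (pyrimidin-5-yl)methyl, for 1-methyl-6-oxopiperidin-3-yl without a shift beyond the scatter.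

Compound 3 `CN1CC(NC(=O)c2ccncc2Nc2cc(-c3ccc4ccn(C)c4c3)c3nccnc3c2)C1` has not yet been measured in this assay. It differs from compound 2 in one place: 1-methylazetidin-3-yl in place of 1-methyl-6-oxopiperidin-3-yl on an amide-type nitrogen. For the measured compounds named here, the only measured step that bears on this position is a 1.1-fold higher number from compound 1 to compound 2 (0.04 log units; within the scatter), which touched the same amide-type nitrogen and was small; no measured step shows the effect of a four-membered ring or of losing the ring carbonyl at this site. On this basis no step beyond the scatter is expected in this assay, in either direction, though the support is thin. Compound 3 is estimated at 120 nM, with a range of 45 nM to 320 nM. The expected step is a 1.0-fold higher number from compound 2 to compound 3 (0.01 log units; within the scatter).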

Compound 3, half-maximal inhibitory concentration: 30 nM
Beside the measured number, compound 3's estimate is 4.0-fold (0.60 log units) above it; the measured number lies below the stated range.
By their numbers in this assay, from the lowest: compound 3; then compounds 1 and 2 (each within the scatter of the next).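

In this assay, for the compounds shown here, the substituent on the amide-type nitrogen turns out to matter: 1-methylazetidin-3-yl in place of 1-methyl-6-oxopiperidin-3-yl gives a 3.9-fold lower number from compound 2 to compound 3 (0.59 log units; beyond the scatter), whereas the only earlier step at this nitrogen stayed within the scatter. The same group in place of (pyrimidin-5-yl)methyl gives a 3.5-fold lower number from compound 1 to compound 3 (0.55 log units; beyond the scatter), so the shift holds against both earlier substituents and compound 3 is the strongest inhibitor of the three on this read-out. No measurement at hand accounts for this shift.

The step from compound 2 to compound 3 shrinks the ring from six-membered to four-membered and removes the ring carbonyl at once, and the compounds shown cannot separate these two changes; 1-methylpiperidin-3-yl or 1-methylpyrrolidin-3-yl on the same amide-type nitrogen would help to divide them. On these data alone, it also remains open whether the methyl on the azetidine ring nitrogen contributes, as azetidin-3-yl or 1-ethylazetidin-3-yl at this place would show.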